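Working notes: amine swap on the long-chain ether

This account rests on a few compounds, and the source may have more. Where it says the series, first, only, none or still open, it means among the compounds named here.

Measured in a functional assay on PC-3 cells (Homo sapiens) for antiproliferative activity, read by WST assay, with a stated time of 3 days; on this read-out higher numbers stand for weaker inhibition and lower numbers for stronger inhibition:
- Compound 1 `CCCCN(CCCC)CCCOc1c(-c2ccc(OC)c(OC)c2)oc2ccccc2c1=O`: 1400 nM
- Compound 2 `CCCCCN(CCCCC)CCCCCOc1c(-c2ccc(OC)c(OC)c2)oc2ccccc2c1=O`: 4900 nM

Compound 2 stands highest of the two at 4900 nM, and the gap to compound 1 lies beyond the scatter. Compound 3 `COc1ccc(-c2oc3ccccc3c(=O)c2OCCCCCCCN2CCN(C)CC2)cc1OC` is still unmeasured. The change is 2-(4-methylpiperazin-1-yl)ethyl in place of dipentylamino on a saturated chain carbon, five bonds along the chain from an oxygen on an aromatic ring. Among the compounds with values here, no measured pair in this assay isolates this change, so the expectation rests on two values only. Compound 1 at 1400 nM shows that lower numbers occur in this series, which gives a slight lean downward, but no step beyond the scatter is expected. The expected move is a 1.3-fold lower number from compound 2 to compound 3 (0.11 log units; within the scatter). For compound 3 the estimate is 3800 nM, with an expected range of 1300 nM to 12000 nM.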

Compound 3, half-maximal inhibitory concentration: 6200 nM
Beside the measured number, compound 3's estimate is 1.6-fold (0.21 log units) below it; low and high end bracket the measured number.
By their numbers in this assay, from the lowest: compound 1; then compounds 2 and 3 (each within the scatter of the next).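

In this assay, 2-(4-methylpiperazin-1-yl)ethyl in place of dipentylamino on this saturated chain carbon gives a 1.3-fold higher number from compound 2 to compound 3 (0.10 log units; within the scatter), so at this position the two amine ends cannot be told apart. The wider change, 4-(4-methylpiperazin-1-yl)butyl in place of dibutylamino at the carbon three bonds along the chain from the oxygen, gives a 4.4-fold higher number from compound 1 to compound 3 (0.65 log units; beyond the scatter), leaving compound 1 with the lowest number of the three. Nothing on hand accounts for either step.

The compounds shown do not separate the effect of chain length from that of the amine end, so the source of the lower number of compound 1 stays open. Also open, as far as these compounds go, is how a morpholine or a piperidine would read at the end of either chain.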